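A Chloro Substituent Where Fluoro Once Sat

The source may hold more compounds than are shown below. What is called first, only, known or untested is meant among the compounds shown, and "the series" means these compounds.

Compound 2 `O=C(NCc1ccc(CNS(=O)(=O)c2ccccc2)cc1)c1ccccc1` stands lowest of the two numbers recorded so far in an assay on MDA-MB-231 cells for binding affinity to C-X-C chemokine receptor type 4 (Homo sapiens), read by immunofluorescence and microscopy, with stated times of 10 min and 30 min (a lower number here means that less compound is needed, a higher number that more compound is needed for the effect), giving 1 nM. Going by the values given here, its only neighbour is compound 1 `O=C(NCc1ccc(CNS(=O)(=O)c2ccccc2)cc1)c1ccccc1F`, which in this assay gives 1000 nM. Among the compounds with values here, the single measured step joins these two: a 1000-fold lower number from compound 1 to compound 2 (3.00 log units; beyond the scatter). Compound 3 `O=C(NCc1ccc(CNS(=O)(=O)c2ccccc2)cc1)c1ccccc1Cl` is not yet measured; its change from compound 2 is chloro in place of hydrogen on an aromatic carbon, on the aromatic carbon ortho to a large group. Within the data shown here, the only step that bears on this change is the one just described, read in reverse: placing a halogen on that carbon raised the number greatly. That halogen was fluoro, and nothing measured here shows how chloro behaves at the same place, so the direction is expected to be a rise and the size uncertain. Compound 3 is expected to give a higher number because a 1000-fold lower number from compound 1 to compound 2 (3.00 log units; beyond the scatter) was large, and the estimated step is a 200-fold higher number from compound 2 to compound 3 (2.30 log units; beyond the scatter). Compound 3 is therefore estimated at 200 nM in this assay, within a range from 10 nM to 3000 nM.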

Compound 3, effective concentration (reported as EC, without a stated level of effect): 10 nM
The estimate for compound 3 lay 20-fold (1.30 log units) above the measured number; measured number inside the range.
By their numbers in this assay, from the lowest: compound 2; then compound 3; then compound 1.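

On this aromatic carbon, ortho to a large group, a halogen now raises the number twice over, since chloro in place of hydrogen gives a 10-fold higher number from compound 2 to compound 3 (1.00 log units; beyond the scatter) in this assay and so joins fluoro in moving the same way. The rise is not the same for the two halogens, however, as exchanging fluoro for chloro gives a 100-fold lower number from compound 1 to compound 3 (2.00 log units; beyond the scatter), so the identity of the halogen matters here and not merely its presence. Nothing available explains why these two halogens differ so widely.

The compounds shown leave open how a group other than a halogen, such as methyl, methoxy or an amine, would read on this same carbon, and whether any of them would match hydrogen. They also leave open whether chloro would behave the same way on another carbon of this ring.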